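Amine side chain exchange on a shared core

This account rests on a few compounds, and the source may have more. Where it says the series, first, only, none or still open, it means among the compounds named here.

Among the measured compounds shown here, in a functional assay on MCF7 cells (Homo sapiens) for antiproliferative activity, with a stated time of 72 h (a higher number here means a weaker inhibitor, a lower number a stronger inhibitor), compound 1 (`COC(=O)CN(C)Cc1c(OC)cc(OC)c(C(=O)/C=C/c2ccccc2Cl)c1O`) gives 10600 nM, the highest number so far, though not clearly separated from every other compound. Compound 2 (`COc1cc(OC)c(C(=O)/C=C/c2ccccc2Cl)c(O)c1CN1CCCC1`) gives 3900 nM, beyond the scatter from compound 1. Compound 3 (`CCN(C)Cc1c(OC)cc(OC)c(C(=O)/C=C/c2ccccc2Cl)c1O`) gives 6800 nM, within the scatter of compound 1.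

Compound 4 (`COc1cc(OC)c(C(=O)/C=C/c2ccccc2Cl)c(O)c1CN(C)CCCN(C)C`) differs from compound 1 as follows: 2-(dimethylamino)ethyl in place of methoxycarbonyl on a saturated chain carbon bound to an amine nitrogen.

Methyl at the same place gives a 1.6-fold lower number from compound 1 to compound 3 (0.19 log units; within the scatter). Exchanging the whole amine for pyrrolidin-1-yl gives a 2.7-fold lower number from compound 1 to compound 2 (0.43 log units; beyond the scatter). For the measured compounds named here, no measured compound carries 2-(dimethylamino)ethyl, so only a modest lowering in this assay is expected, possibly none beyond the scatter.

The expected step is a 2.1-fold lower number from compound 1 to compound 4 (0.33 log units; beyond the scatter). The estimated value for compound 4 is 5000 nM, with an expected range of 2000 nM to 12000 nM.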

Compound 4, half-maximal inhibitory concentration: 3200 nM
Beside the measured number, compound 4's estimate is 1.6-fold (0.19 log units) above it; the measured number falls inside the stated range.
By their numbers in this assay, from the lowest: compounds 4, 2, 3 and 1 (each within the scatter of the next, the first and the last beyond it).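

In this assay, extending the ethyl chain of compound 3 with (dimethylamino)methyl gives a 2.1-fold lower number from compound 3 to compound 4 (0.33 log units; beyond the scatter), so a step beyond the scatter appears among the open-chain amines at this position. Replacing methoxycarbonyl with 2-(dimethylamino)ethyl gives a 3.3-fold lower number from compound 1 to compound 4 (0.52 log units; beyond the scatter), while the open chain with its second amine and the pyrrolidine show no separation, with a 1.2-fold lower number from compound 2 to compound 4 (0.09 log units; within the scatter). No evidence is available to explain these steps.

Still open, going by these compounds, is whether the second amine or the added chain length accounts for the step from compound 3. A plain butyl chain on the same nitrogen would separate the two.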